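This account rests on a few compounds, and the source may have more. Where it says the series, first, only, none or still open, it means among the compounds named here.

Three dithiocarbamate-bearing chromenones have been measured in a functional assay on SW480 cells (Homo sapiens) for antiproliferative activity, read by MTT assay, with a stated time of 72 h; a lower number here means a stronger inhibitor, a higher number a weaker inhibitor. Compound 1 `O=c1c(CSC(=S)N2CCN(c3ccccc3)CC2)coc2ccccc12` gives 5200 nM. Compound 2 `O=c1cc(CSC(=S)N2CCCCC2)oc2cc(Cl)ccc12` gives 2500 nM. Compound 3 `COc1ccc2oc(CSC(=S)N3CCCCC3)cc(=O)c2c1` gives 2300 nM. Among these three numbers compound 2 stands second highest: its nearest neighbour is compound 3, whose number is lower by a margin that lies within the scatter of repeat measurements, while compound 1 stands furthest away, with a number higher than that of compound 2 by a margin beyond the scatter.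

Compound 4 `O=c1cc(CSC(=S)N2CCOCC2)oc2cc(Cl)ccc12` has not yet been measured. It differs from compound 2 in one place: morpholin-4-yl in place of piperidin-1-yl on a thiocarbonyl carbon. Among the measured compounds shown here, no measured pair in this set shows what this exchange does in this assay, so no step can be read from the data. Since nothing here shows the exchange moving the number clearly in either direction, the step from compound 2 to compound 4 is expected to be small, a 1.2-fold higher number from compound 2 to compound 4 (0.08 log units; within the scatter), not beyond the scatter. Compound 4 is therefore estimated at 3000 nM, within a range from 1200 nM to 8000 nM.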

Compound 4, half-maximal inhibitory concentration: > 25000 nM
Compound 4: only a limit was reported; the forecaster's own chance of this, stated with the estimate: 5%; middle value at least 8.3-fold (0.92 log units) from the limit.
By their numbers in this assay, from the lowest: compounds 3 and 2 (each within the scatter of the next); then compound 1. At a limit, above all of these: compound 4.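

In this assay, the group on the thiocarbonyl carbon proves far from neutral: morpholin-4-yl in place of piperidin-1-yl gives an at least 10-fold higher number from compound 2 to compound 4 (1.00 log units; beyond the scatter). The two groups have the same ring size and the same count of heavy atoms, so a single exchange of one ring carbon for oxygen, which adds one hydrogen-bond acceptor, is enough to carry the number well beyond the scatter. For compound 4 the reported figure is a limit and not a number: the limit of > 25000 nM in this assay, at which 1 of the 4 values shown sits.

The compounds shown leave open whether the ring oxygen itself accounts for the step, since this single pair cannot separate it from the loss of the ring carbon. They also leave open how an open-chain diethylamino group or a piperazin-1-yl ring with a free amine would behave at this place on the core of compound 2.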